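The compounds below may be only part of what the source reports. "The series", "measured", "known", "first", "only" and "open" are said of these compounds alone.

Measured in a functional assay on BaF3 cells (Mus musculus) for antiproliferative activity, read by CCK-8 assay and cell counting, with a stated time of 76 h; a higher number here means a weaker inhibitor, a lower number a stronger inhibitor:
Compound 1 `COc1cc2nccc(Oc3ccc(Nc4nn(C)cc4C(=O)NCC4CCCO4)cc3)c2cc1C(N)=O`: > 10000 nM (a limit)
Compound 2 `COc1cc2nccc(Oc3ccc(Nc4nn(C)cc4C(=O)Nc4ccccc4F)cc3)c2cc1C(N)=O`: 1710 nM

The result for compound 1 is a limit, > 10000 nM. Among the compounds with values here, compound 2 gives 1710 nM, the only true number so far in this assay.

Compound 3 `COc1cc2nccc(Oc3ccc(Nc4nn(C)cc4C(=O)Nc4cccc(F)c4)cc3)c2cc1C(N)=O` has the same atoms as compound 2, joined differently: 3-fluorophenyl in place of 2-fluorophenyl on an amide-type nitrogen. Within the data shown here, only one measured step touches this amide-type nitrogen, an at least 5.8-fold lower number from compound 1 to compound 2 (0.76 log units; beyond the scatter). That step shows that the group carried here can change the result, but it exchanged (oxolan-2-yl)methyl and does not compare 2-fluorophenyl with 3-fluorophenyl. It therefore gives only loose guidance, and no direction for the new change. The expected result is a small change or none beyond the scatter, though with wide uncertainty: a 1.1-fold lower number from compound 2 to compound 3 (0.03 log units; within the scatter) is the estimated step. For compound 3 the expected value is 1600 nM, with an estimated range of 500 nM to 6000 nM.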

Compound 3, half-maximal inhibitory concentration: 4480 nM
Estimate against measurement, compound 3: 2.8-fold (0.45 log units) below, and the stated range covers the measured number.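

Exchanging 2-fluorophenyl for 3-fluorophenyl on the amide-type nitrogen, with the same atoms joined differently, still registers in this assay, giving a 2.6-fold higher number from compound 2 to compound 3 (0.42 log units; beyond the scatter), so this position responds to where the fluorine sits on the phenyl group and not only to exchange of the whole group. The 3-fluorophenyl group still improves on (oxolan-2-yl)methyl, with an at least 2.2-fold lower number from compound 1 to compound 3 (0.34 log units; beyond the scatter). Compound 1 is a limit and not a number, so that step gives only a bound: the limit of > 10000 nM in this assay, at which 1 of the 3 values shown sits.

The compounds shown leave open whether a phenyl group with no fluorine would give a lower or a higher number than either fluorophenyl group. They also leave open whether a chlorine in place of the fluorine would preserve the difference between compound 2 and compound 3.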